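The source may report more compounds than this note shows. Statements on the series, on what has been measured and on what is new or still open speak of the compounds shown alone.

Series in a functional assay on MCF7 cells (Homo sapiens) for inhibition, read by sulforhodamine B assay; on this read-out lower numbers stand for stronger inhibition of growth and higher numbers for weaker inhibition of growth:
- compound 1 `c1ccc(-c2ccc(-c3ccc(-c4nc5ccccc5[nH]4)cc3)cc2)cc1`: 39200 nM
- compound 2 `Cc1ccc2[nH]c(-c3ccc(-c4ccc(-c5ccc(N(C)C)cc5)cc4)cc3)nc2c1`: 3130 nM
- compound 3 `Oc1cccc2[nH]c(-c3ccc(-c4ccc(-c5ccccc5)cc4)cc3)nc12`: 2200 nM

Compound 3 stands at the low end of these numbers, and compound 2 lies within the scatter of it. Within the data shown here, the one measured step, an 18-fold lower number from compound 1 to compound 3 (1.25 log units; beyond the scatter), is large and beyond the scatter. That step is hydroxy in place of hydrogen on an aromatic carbon.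

The unmeasured compound 4 `Oc1cccc2[nH]c(-c3ccc(-c4ccc(-c5ccc(C(F)(F)F)cc5)cc4)cc3)nc12` departs from compound 3 by trifluoromethyl in place of hydrogen on an aromatic carbon. Among the measured compounds shown here, the hydroxy step bears on this change only indirectly, since it concerns a different group, and no measured pair shows trifluoromethyl entering. Its size is therefore not carried over. Compound 4 keeps the hydroxy group of compound 3, so the expected starting point is the value of compound 3 at 2200 nM. For the measured compounds named here, with no measured step for this change, no step beyond the scatter is expected in this assay, and no direction can be assigned with confidence. The expected size is a 1.1-fold higher number from compound 3 to compound 4 (0.06 log units; within the scatter). The estimate for compound 4 is 2500 nM, with an expected range from 800 nM to 8000 nM.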

Compound 4, concentration for 50% growth inhibition: 2310 nM
Beside the measured number, compound 4's estimate is 1.1-fold (0.03 log units) above it; the range from low to high includes it.
By their numbers in this assay, from the lowest: compounds 3, 4 and 2 (each within the scatter of the next); then compound 1.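

In this assay, the change from phenyl to 4-(trifluoromethyl)phenyl gives a 1.1-fold higher number from compound 3 to compound 4 (0.02 log units; within the scatter), so with the hydroxy group in place, this position accepts trifluoromethyl, a group of four heavy atoms, with no step beyond the scatter. This pair is the only one shown for a substituent at this place, on an aromatic carbon para to a large group, and it shows a very different outcome from the hydroxy change, an 18-fold lower number from compound 1 to compound 3 (1.25 log units; beyond the scatter), which remains the only large single-place step in the series. No available data explain why the trifluoromethyl change leaves the number within the scatter.

From the compounds shown here alone, it remains open whether the same result extends to other groups at this place, such as a carboxylic acid, an amine or a longer alkyl chain, since one group at one position cannot define what the position accepts. It is also open whether trifluoromethyl would give a similar step on the core of compound 1, without the hydroxy group, as the only pair shown for this change carries that hydroxy group on both sides.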